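Cinnamic acid series: naphthyl in place of phenoxyethyl

The compounds below may be only part of what the source reports. "The series", "measured", "known", "first", "only" and "open" are said of these compounds alone.

Working notes. Compound 2 `O=C(O)/C=C/c1ccc(Cn2ccnc2)cc1OCCCCOc1ccccc1` stands only at a limit on the numbers shown. In an assay on CHO cells for displacement of a labelled ligand from prostaglandin E2 receptor EP2 subtype (Mus musculus), read by scintillation counting (a lower number here means a stronger inhibitor, a higher number a weaker inhibitor), compound 2 gives > 10000 nM, which is a limit of the assay and not a number. Compound 1 `O=C(O)/C=C/c1ccc(Cn2ccnc2)cc1OCCCOc1ccccc1` gives in this assay > 10000 nM, likewise a limit. Among the measured compounds shown here, the one measured step, a step that the two limits leave unreadable from compound 1 to compound 2, is therefore unreadable, both values sitting at the limit of > 10000 nM in this assay, at which 2 of the 2 values shown sit. Compound 3 `O=C(O)/C=C/c1ccc(Cn2ccnc2)cc1OCCc1ccc2ccccc2c1` differs from compound 2 by naphthalen-2-yl in place of 2-phenoxyethyl on a saturated chain carbon, two bonds along the chain from an oxygen on an aromatic ring. No measured step bears readably on this change, so the size of the step in this assay cannot be taken from the pair shown, and the only expectation the data support is that compound 3 may again sit at the limit. The estimated step is a step that the limit leaves unreadable from compound 2 to compound 3, meaning no readable change is expected. Compound 3 is expected to give about 12000 nM in this assay, within 2000 nM to 60000 nM.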

Compound 3, inhibition constant: > 10000 nM
Compound 3: only a limit was reported; the forecaster's own chance of this, stated with the estimate: 75%; the middle value does not contradict the limit.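

In this assay compound 3 gives > 10000 nM, a limit and not a number, so no step from compound 1 or compound 2 to compound 3 can be read: the limit of > 10000 nM in this assay, at which 3 of the 3 values shown sit.

The compounds shown leave open which change to the shared core, if any, would give a readable value in this assay.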